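The source may hold more compounds than are shown below. What is called first, only, known or untested is meant among the compounds shown, and "the series" means these compounds.

Measured compounds:
compound 1 `C=CC(=O)Nc1cc(SC)ccc1Nc1ncc2cc(-c3c(Cl)c(OC)cc(OC)c3Cl)ccc2n1`: 936 nM
compound 2 `C=CC(=O)Nc1cc(S(C)(=O)=O)ccc1Nc1ncc2cc(-c3c(Cl)c(OC)cc(OC)c3Cl)ccc2n1`: 2160 nM

In a functional assay on Huh-7 cells (Homo sapiens) for inhibition, read by sulforhodamine B assay, with a stated time of 72 h (a lower number here means a stronger inhibitor, a higher number a weaker inhibitor), compound 2 gives the higher of the two numbers, and its nearest neighbour is compound 1, because of a 2.3-fold higher number from compound 1 to compound 2 (0.36 log units; beyond the scatter). Compound 3 `C=CC(=O)Nc1cc(S(=O)(=O)NC(=O)C=C)ccc1Nc1ncc2cc(-c3c(Cl)c(OC)cc(OC)c3Cl)ccc2n1` is not yet measured. It differs from compound 2 by (vinylcarbonyl)amino in place of methyl on a sulfonyl sulfur. Among the measured compounds shown here, only one measured step touches this part of the molecule, and that step, a 2.3-fold higher number from compound 1 to compound 2 (0.36 log units; beyond the scatter), changed the group on the aromatic carbon rather than what sits on the sulfonyl sulfur itself, so it offers only a loose guide. For the measured compounds named here, no measured pair shows what adding a (vinylcarbonyl)amino to that sulfur does. The expectation for compound 3 is therefore a number close to compound 2, with a step of a 1.2-fold higher number from compound 2 to compound 3 (0.06 log units; within the scatter) that may not go beyond the scatter. Compound 3 is estimated at 2500 nM, with a range from 900 nM to 7000 nM.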

Compound 3, half-maximal inhibitory concentration: 4750 nM
Compound 3: middle estimate off by 1.9-fold (0.28 log units), on the low side, and the stated range covers the measured number.
By their numbers in this assay, from the lowest: compound 1; then compound 2; then compound 3.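

In this assay, what sits on the sulfonyl sulfur matters: (vinylcarbonyl)amino in place of methyl gives a 2.2-fold higher number from compound 2 to compound 3 (0.34 log units; beyond the scatter) and shows that this position responds to a change on the sulfur itself, and not only to a change on the aromatic carbon. Taken together with the earlier change, the move from methylsulfanyl to (vinylcarbonyl)sulfamoyl gives a 5.1-fold higher number from compound 1 to compound 3 (0.71 log units; beyond the scatter) and points towards a weaker inhibitor, as both single steps at this position do. Nothing measured here explains these steps.

Going by these compounds, it remains open whether the added nitrogen or the vinylcarbonyl part accounts for the step from the methyl compound. A plain amino group or an acetylamino group on the sulfonyl sulfur would help tell these two parts apart.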